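The source may report more compounds than this note shows. Statements on the series, on what has been measured and on what is new or still open speak of the compounds shown alone.

Three compounds share one core and were tested in a functional assay on CHO cells for agonist activity at Melanocortin receptor 4 (Homo sapiens), read by a luciferase reporter, with a stated time of 4 h; a higher number here means that more compound is needed for the effect, a lower number that less compound is needed. Compound 1 `COc1ccc(N(C(=O)CN2C=CN(c3ccccc3)C(=O)C(Cc3n[nH]c4ccccc34)C2=O)C(C)C)cc1` gives 708 nM. Compound 2 `O=C1[C@@H](Cc2n[nH]c3ccccc23)C(=O)N(c2ccccc2)C=CN1CC(=O)N1CCCCc2ccccc21` gives 100 nM. Compound 3 `O=C1C(Cc2n[nH]c3cc(F)ccc23)C(=O)N(c2ccccc2)C=CN1CC(=O)N1CCCCc2ccccc21` gives 437 nM, which is the second highest of the three numbers: compound 1 sits nearest, at a number higher than that of compound 3 but within the usual scatter, while compound 2 sits furthest, at a number lower than that of compound 3 by a margin beyond the scatter.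

Compound 4 `O=C1C(Cc2n[nH]c3ccccc23)C(=O)N(c2ccccc2)C=CN1CC(=O)N1CCCCc2ccccc21` is made from compound 3 by one change: hydrogen in place of fluoro on an aromatic carbon. Within the data shown here, no measured pair in this set shows exactly this change in isolation. What the set does hold is compound 2, whose structure matches compound 4 apart from the fact that compound 2 is drawn with one carbon fixed in a single spatial arrangement, while compound 4 is drawn without that fixing.

Because compound 2 gives 100 nM with the fluoro already absent, compound 4 is expected to move downward from compound 3 in this assay by the step of a 2.4-fold lower number from compound 3 to compound 4 (0.39 log units; beyond the scatter). Compound 4 is therefore estimated at 180 nM, with a range from 70 nM to 450 nM.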

Compound 4, half-maximal effective concentration: 324 nM
Estimate against measurement, compound 4: 1.8-fold (0.26 log units) below; low and high end bracket the measured number.
By their numbers in this assay, from the lowest: compound 2; then compounds 4, 3 and 1 (each within the scatter of the next, the first and the last beyond it).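

In this assay, hydrogen in place of fluoro on this aromatic carbon of the six-membered aromatic ring gives a 1.3-fold lower number from compound 3 to compound 4 (0.13 log units; within the scatter), so this pair shows no clear effect of the fluoro at this place. The larger shift seen among these compounds appears at the stereocentre, where the same atoms and bonds give a 3.2-fold higher number from compound 2 to compound 4 (0.51 log units; beyond the scatter), and one feature sets this pair apart: the fact that one of compounds 2 and 4 is drawn with a defined configuration and the other without, at the place where they differ. On the carbonyl carbon, the group with the seven-membered non-aromatic ring, in place of the group with only a six-membered aromatic ring, gives a 2.2-fold lower number from compound 1 to compound 4 (0.34 log units; beyond the scatter), a modest step that now rests on a pair differing in that one place, with neither partner's stereocentre drawn with a configuration.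

The compounds shown leave open what the form drawn S at the stereocentre would give on its own, and so how each form contributes to the number of compound 4. They also leave open whether a chloro, a methoxy or an amine on this aromatic carbon would stay as close to hydrogen as fluoro does, and whether fluoro would matter in the form drawn R.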